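This account rests on a few compounds, and the source may have more. Where it says the series, first, only, none or still open, it means among the compounds named here.

- compound 1 `O=[N+]([O-])c1ccc(-c2nnc(SCCCN3CCN(c4nc5ccccc5o4)CC3)o2)cc1` gives 67200 nM
- compound 2 `Oc1ccc(-c2nnc(SCCCN3CCN(c4nc5ccccc5o4)CC3)o2)cc1` gives 502000 nM
- compound 3 `O=[N+]([O-])c1ccc(-c2nnc(SCCCN3CCN(c4nc5ccccc5s4)CC3)o2)cc1` gives 93300 nM
- compound 4 `c1ccc(-c2nnc(SCCCN3CCN(c4nc5ccccc5s4)CC3)o2)cc1` is not yet measured

These numbers come from a functional assay on HepG2 cells (Homo sapiens) for inhibition, read by MTT assay, with a stated time of 72 h (a lower number here means a stronger inhibitor, a higher number a weaker inhibitor), and compound 3 sits level with compound 1, as a 1.4-fold higher number from compound 1 to compound 3 (0.14 log units; within the scatter) shows, while compound 2 has a clearly higher number than both. The change to compound 4 removes the nitro group, leaving hydrogen in place of nitro on an aromatic carbon (4-nitrophenyl to phenyl). The nearest guide is the other step that removes nitro, a 7.5-fold higher number from compound 1 to compound 2 (0.87 log units; beyond the scatter) in which hydroxy enters rather than hydrogen. Within the data shown here, no measured compound carries hydrogen at that place, so this guide is only indirect. The swap in the first step above left the number within the scatter, so the nitro step may well carry over to compound 3. A smaller upward step is therefore expected in this assay and it may land near the edge of the scatter. The estimated change is a 1.9-fold higher number from compound 3 to compound 4 (0.29 log units; within the scatter) on this reasoning. Compound 4 is expected at 180000 nM with an estimated range from 70000 nM to 450000 nM around that value.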

Compound 4, half-maximal inhibitory concentration: 217000 nM
Compound 4: middle estimate off by 1.2-fold (0.08 log units), on the low side; the range from low to high includes it.
By their numbers in this assay, from the lowest: compounds 1 and 3 (each within the scatter of the next); then compound 4; then compound 2.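

Among these compounds, compound 4 gives the first direct reading of plain hydrogen at this position on the aromatic ring: in this assay there is a 2.3-fold higher number from compound 3 to compound 4 (0.37 log units; beyond the scatter) as the only change. Losing the nitro group therefore raises the number even when no hydroxy group enters, and the other step that removes nitro, a 7.5-fold higher number from compound 1 to compound 2 (0.87 log units; beyond the scatter) on the 1,3-benzoxazol-2-yl side, points the same way, with no pair shown going against it. Nothing measured here explains why the number rises at this position.

The compounds shown leave open how an amino group, a methoxy group or a carboxylic acid would read at this same place on the ring. They also leave open how plain phenyl behaves alongside 1,3-benzoxazol-2-yl, and what a longer chain in the linker would do.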